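The compounds below may be only part of what the source reports. "The series", "measured", "known", "first", "only" and "open" are said of these compounds alone.

Measured compounds:
compound 1, `Cc1ccc(OCC(=O)N(Cc2cccs2)c2ncco2)cc1`, 0.3 nM
compound 2, `Cc1ccc(OCC(=O)N(Cc2cccs2)c2c(C)n[nH]c2C)cc1`, 0.3 nM
compound 3, `Cc1ccc(OCC(=O)N(Cc2cccs2)c2ncccn2)cc1`, 3700 nM

In an assay on HEK293 cells for agonist activity at transient receptor potential cation channel subfamily M member 8 (Homo sapiens), read by fluorescence and calcium flux, with a stated time of 15 min (a higher number here means that more compound is needed for the effect, a lower number that less compound is needed), compound 3 gives the highest of the three numbers, and both neighbours lie far from it: the step of a 12000-fold higher number from compound 1 to compound 3 (4.09 log units; beyond the scatter) and the step of a 12000-fold higher number from compound 2 to compound 3 (4.09 log units; beyond the scatter) are each large and well beyond the scatter, while compound 1 and compound 2 sit within the scatter of each other. Compound 4, `Cc1ccc(OCC(=O)N(Cc2cccs2)C2CC2)cc1`, differs from compound 3 by cyclopropyl in place of pyrimidin-2-yl on an amide-type nitrogen. Within the data shown here, no measured step exchanges the group on this nitrogen for a non-aromatic ring, so the two large steps only show that the group on the amide-type nitrogen governs the number in this assay and that leaving pyrimidin-2-yl can lower it by a great deal. A cyclopropyl group is expected to move the number downward from compound 3 by a 74-fold lower number from compound 3 to compound 4 (1.87 log units; beyond the scatter), though with wide uncertainty. Compound 4 is therefore estimated at 50 nM, between 2 nM and 1500 nM.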

Compound 4, half-maximal effective concentration: 8 nM
Compound 4: the middle estimate sits 6.3-fold (0.80 log units) above what was measured; the measured number falls inside the stated range.
By their numbers in this assay, from the lowest: compounds 1 and 2 (each within the scatter of the next); then compound 4; then compound 3.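

In this assay, a non-aromatic ring on the amide-type nitrogen can still give a low number: cyclopropyl in place of pyrimidin-2-yl brings a 460-fold lower number from compound 3 to compound 4 (2.67 log units; beyond the scatter), so an aromatic ring is not required here. Cyclopropyl does not match the best groups, though: in place of 1,3-oxazol-2-yl it gives a 27-fold higher number from compound 1 to compound 4 (1.43 log units; beyond the scatter), and in place of 3,5-dimethyl-1H-pyrazol-4-yl it gives a 27-fold higher number from compound 2 to compound 4 (1.43 log units; beyond the scatter). Aromatic groups therefore fall on both sides of cyclopropyl, with pyrimidin-2-yl on the high side, so aromatic against non-aromatic does not by itself order the numbers at this position.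

No supporting data bear on why the groups fall in this order. From the compounds shown here alone, it remains open whether an ethyl chain, a cyclohexyl ring or an amine on this nitrogen would fall nearer to compound 1 and compound 2 or to compound 3.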